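Chloro in place of methoxy: a growth-inhibition estimate

This account rests on a few compounds, and the source may have more. Where it says the series, first, only, none or still open, it means among the compounds named here.

Measured in a functional assay on U-251 cells (Homo sapiens) for inhibition, read by MTT assay, with a stated time of 2 days; on this read-out lower numbers stand for stronger inhibition of growth and higher numbers for weaker inhibition of growth:
- compound 1 `Nc1ccccc1NC(=O)c1ccc(NCC(=O)Nc2ccc([N+](=O)[O-])cc2)cc1` gives 8200 nM
- compound 2 `Cc1ccc(NC(=O)CNc2ccc(C(=O)Nc3ccccc3N)cc2)cc1` gives 84000 nM
- compound 3 `COc1ccc(NC(=O)CNc2ccc(C(=O)Nc3ccccc3N)cc2)cc1` gives 25500 nM

Compound 3 holds the second highest of these three numbers, with compound 1 lower and compound 2 higher. Compound 4 `Nc1ccccc1NC(=O)c1ccc(NCC(=O)Nc2ccc(Cl)cc2)cc1` has chloro in place of methoxy on an aromatic carbon, para to a large group (chloro in place of methoxy on an aromatic carbon). Exchanging the group at this place has already mattered in this assay: the measured steps are a 3.1-fold higher number from compound 1 to compound 3 (0.49 log units; beyond the scatter), a 3.3-fold lower number from compound 2 to compound 3 (0.52 log units; beyond the scatter) and, largest, a 10-fold higher number from compound 1 to compound 2 (1.01 log units; beyond the scatter). None of these compounds carries chloro, so the direction is uncertain. A modest move to a lower number is expected, and the step estimated is a 2.1-fold lower number from compound 3 to compound 4 (0.33 log units; beyond the scatter). For compound 4 the expected value is 12000 nM, with an estimated range from 4000 nM to 40000 nM.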

Compound 4, concentration for 50% growth inhibition: 9400 nM
Estimate against measurement, compound 4: 1.3-fold (0.11 log units) above, and the stated range covers the measured number.
By their numbers in this assay, from the lowest: compounds 1 and 4 (each within the scatter of the next); then compound 3; then compound 2.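

In this assay nitro no longer stands alone at the low end of this aromatic carbon: chloro matches it (a 1.1-fold higher number from compound 1 to compound 4 (0.06 log units; within the scatter)). Both methoxy (a 2.7-fold lower number from compound 3 to compound 4 (0.43 log units; beyond the scatter)) and methyl (an 8.9-fold lower number from compound 2 to compound 4 (0.95 log units; beyond the scatter)) give clearly higher numbers than chloro, so a second, quite different group now shares the lowest level seen at this position. Nothing here gives a measured reason for these steps.

Going by these compounds, whether an amine, a carboxylic acid or a bromo group at this place would sit level with compound 1 and compound 4 remains open.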